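The compounds below may be only part of what the source reports. "The series", "measured", "known", "first", "only" and "open" are said of these compounds alone.

Measured so far:
compound 1, `Fc1ccc(Nc2nc(-c3cccc(F)c3)nc3ccc(F)cc23)cc1` — in a functional assay on MDA-MB-231 cells (Homo sapiens) for cytotoxicity, read by MTT assay, with a stated time of 48 h (a higher number here means a weaker inhibitor, a lower number a stronger inhibitor), compound 1 gives only the limit > 50000 nM, not a number.
compound 2, `Fc1cccc(Nc2nc(-c3cccc(F)c3)nc3ccc(F)cc23)c1` — in this assay compound 2 gives 47600 nM.

Among the compounds with values here, compound 2 thus stands as the only actual number in the set; the other value is a limit, and the limit of > 50000 nM in this assay, at which 1 of the 2 values shown sits, describes where it sits. Within the data shown here, the single measured step, an at least 1.0-fold lower number from compound 1 to compound 2 (0.02 log units; that floor lies within the scatter), moves 3-fluorophenyl in place of 4-fluorophenyl on the ring nitrogen and rests on a limit at one end, so it shows no more than that both compounds are weak.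

Compound 3, `Fc1cccc(-c2nc(Nc3cccc(Cl)c3)c3cc(F)ccc3n2)c1`, differs from compound 2 by chloro in place of fluoro on an aromatic carbon. Among the measured compounds shown here, no measured step involves a halogen exchange at this position, so none bears directly on it; the one step in hand concerns the position of the fluorine, not its identity, and lies within the scatter. For compound 3 the step of a 1.2-fold lower number from compound 2 to compound 3 (0.08 log units; within the scatter) is therefore expected to stay within the scatter, with the weak activity of compound 2 carried over. The estimate for compound 3 is 40000 nM, with a range from 15000 nM to 100000 nM, and a fair chance that only a limit is reported.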

Compound 3, half-maximal inhibitory concentration: > 50000 nM
Compound 3: a limit, no number (the forecaster's own chance of this, stated with the estimate: 40%); at least 1.2-fold (0.09 log units) between middle value and limit.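

Chloro in place of fluoro on this aromatic carbon, which turns (3-fluorophenyl)amino into (3-chlorophenyl)amino, is the first change of halogen identity in the series, and in this assay it gives an at least 1.0-fold higher number from compound 2 to compound 3 (0.02 log units; that floor lies within the scatter). The earlier step concerned only where the fluorine sits, whereas this one shows that exchanging the halogen itself brings no readable gain in this read-out, so the weak level of compound 2 is not improved by chloro here. The step between compound 1 and compound 3 cannot be read, and two of the three compounds now give only a limit, not a number: the limit of > 50000 nM in this assay, at which 2 of the 3 values shown sit.

From the compounds shown here alone, whether an amine or a carboxylic acid in place of the halogen on this ring would give a clearly lower number in this assay stays open. Going by these compounds, the true size of the difference between fluoro and chloro at this carbon also stays open, and so does whether any halogen here matters at all for the cytotoxicity read-out.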